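A few compounds are considered here, and "the series" means these few. Any claim that something is new, unique, unknown or untested is made for them only; others in the source may bear on it.

In a toxicity assay on A549 cells (Homo sapiens) for cytotoxicity, read by luminescence and CellTiter-Glo, with a stated time of 48 h (on this read-out higher numbers stand for lower toxicity in this test and lower numbers for higher toxicity in this test), compound 1 (`CCCCOc1ccc(-c2nc3ncccn3c2NCC2CC2)cc1`) gives > 100000 nM, which is a limit and not a number. Compound 2 (`O=C(O)CCCOc1ccc(-c2nc3ncccn3c2NC2CCCCC2)cc1`) gives > 100000 nM, also a limit. The data so far therefore show only (the limit of > 100000 nM in this assay, at which 2 of the 2 values shown sit). Compound 3 (`Fc1ccc(-c2nc3ncccn3c2NC2CCCCC2)cc1`) differs from compound 2 by fluoro in place of 3-carboxypropoxy on an aromatic carbon. Since compound 2 gives > 100000 nM, only a small step toward lower numbers, if any, is expected in this assay. The expected step is a number no higher from compound 2 to compound 3 (the limit leaves the size open). For compound 3, the estimate is 100000 nM, with an expected range from 40000 nM to 100000 nM.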

Compound 3, half-maximal cytotoxic concentration: 100000 nM
Compound 3: the middle estimate sits on the measured number at the digits printed; low and high end bracket the measured number.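

Going by these compounds alone, compound 3 is the first compound here to give a number and not a limit in this assay, with fluoro in place of 3-carboxypropoxy on the aromatic carbon. Compound 2 gives > 100000 nM, which is a limit. The change can therefore be described only as a number no higher from compound 2 to compound 3 (the limit leaves the size open), and its size cannot be read.

From the compounds shown here alone, it remains open how an amine or a nitrile on this aromatic carbon would read in this assay. Also open, going by these compounds, is whether any group at this place brings the number clearly lower.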